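Isopropyl ester on the larger ring: the next point

The compounds below may be only part of what the source reports. "The series", "measured", "known", "first", "only" and "open" are said of these compounds alone.

Three thiourea esters on the shared core have been run in an assay on HEK-Blue hTLR2 cells for agonist activity at Toll-like receptor 2 (Homo sapiens), with a stated time of 24 h; a lower number here means that less compound is needed, a higher number that more compound is needed for the effect. Compound 1 `COC(=O)c1c(NC(=S)Nc2ccc(C(F)(F)F)cc2)sc2c1CCCC2` gives 33900 nM. Compound 2 `COC(=O)c1c(NC(=S)Nc2cccc3ccccc23)sc2c1CCCC2` gives 7330 nM. Compound 3 `CC(C)OC(=O)c1c(NC(=S)Nc2cccc3ccccc23)sc2c1CCC2` gives 180 nM. On these numbers compound 2 stands second highest of the three: compound 1 sits clearly higher, compound 3 clearly lower, and both gaps lie beyond the scatter. Compound 2 and compound 3 differ in two places at once, so their values alone say nothing about either change on its own.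

The next compound, compound 4 `CC(C)OC(=O)c1c(NC(=S)Nc2cccc3ccccc23)sc2c1CCCC2`, differs from compound 2 in a single place: isopropyl in place of methyl on an oxygen next to a carbonyl group. The ester is thus brought to the form present in compound 3 while the rest of compound 2 is kept. Among the measured compounds shown here, no measured pair isolates this change, so the size of the step is open. The expectation is that in this assay compound 4 moves toward the lower value of compound 3 180 nM rather than staying near compound 2, and the step from compound 2 to compound 4 is estimated as a 10-fold lower number from compound 2 to compound 4 (1.02 log units; beyond the scatter), downward and beyond the scatter. Compound 4 is accordingly estimated at 700 nM, with a range from 150 nM to 3000 nM.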

Compound 4, half-maximal effective concentration: 140 nM
Beside the measured number, compound 4's estimate is 5.0-fold (0.70 log units) above it; the whole stated range lies above it.
By their numbers in this assay, from the lowest: compounds 4 and 3 (each within the scatter of the next); then compound 2; then compound 1.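

Isopropyl in place of methyl on an oxygen next to a carbonyl group is the first change in this series that can be read on its own, and in this assay it gives a 52-fold lower number from compound 2 to compound 4 (1.72 log units; beyond the scatter) with the rest of compound 2 kept, so this position alone can carry a large shift in the number. At the isopropyl ester, compound 3 gives 180 nM and compound 4 gives 140 nM and these values lie within the scatter of each other, so the difference in ring size between the two brings no readable change in this pair. Nothing at hand bears on the reason for the size of the step.

The compounds shown leave open whether the number keeps falling with an ethyl, tert-butyl or longer chain on this oxygen, and how a carboxylic acid or an amide would read at the same place. They also leave open whether the same change holds on the trifluoromethyl-bearing compound 1, or whether the step seen here depends on the rest of compound 2.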